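This account rests on a few compounds, and the source may have more. Where it says the series, first, only, none or still open, it means among the compounds named here.

Compound 1 `N#Cc1ccc(CN(C(=O)Nc2cc(C(F)(F)F)cc(C(F)(F)F)c2)n2cnnc2)cc1` gives 9280 nM in a functional assay on MDA-MB-231 cells (Homo sapiens) for cytotoxicity, read by MTT assay, with a stated time of 48 h; a higher number here means a weaker inhibitor, a lower number a stronger inhibitor.
Compound 2 `COc1ccc(OC)c(CN(C(=O)Nc2ccc(C)cc2)n2cnnc2)c1` gives > 50000 nM in this assay, which is a limit of the assay and not a number.

Compound 2 thus stands at the limit of this assay the limit of > 50000 nM in this assay, at which 1 of the 2 values shown sits: no number is known for it, only that it falls beyond what the assay reports. Compound 3 `CCCCCCCCCNC(=O)N(Cc1cc(OC)ccc1OC)n1cnnc1` differs from compound 2 in one place: nonyl in place of 4-methylphenyl on an amide-type nitrogen. Among the measured compounds shown here, no measured pair here differs in a single place, so no step is known against which this change could be scaled. The step of an at least 1.1-fold lower number from compound 2 to compound 3 (0.04 log units; that floor lies within the scatter) is expected to stay within the scatter, with a limit again a likely outcome. Compound 3 is expected to give 45000 nM in this assay, in a range from 12000 nM to 150000 nM.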

Compound 3, half-maximal inhibitory concentration: > 50000 nM
Compound 3: only a limit was reported; the forecaster's own chance of this, stated with the estimate: 55%; middle value at least 1.1-fold (0.04 log units) from the limit.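

Compound 3 gives > 50000 nM in this assay, which is a limit of the assay and not a number. Compound 2 also stands at a limit, so no step can be read from it to compound 3. The compounds shown leave open what nonyl in place of 4-methylphenyl does to the value.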